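Swapping a ring for an open chain on the amine

A few compounds are considered here, and "the series" means these few. Any claim that something is new, unique, unknown or untested is made for them only; others in the source may bear on it.

Measured so far:
- compound 1, `COc1cccc(-n2cc3nc(-c4cccnc4C)n(C[C@H]4CCCN(CC5CCOC5)C4)c(=O)c3n2)c1`: 60 nM
- compound 2, `Cc1ncccc1-c1nc2cn(-c3ccc(C#N)cc3)nc2c(=O)n1CC1CCCN(C2COC2)C1`: 4000 nM

In an assay on HEK293 cells for displacement of a labelled ligand from growth hormone secretagogue receptor type 1 (Homo sapiens), with a stated time of 60 min (a higher number here means a weaker inhibitor, a lower number a stronger inhibitor), compound 1 gives the lower of the two numbers. Among the measured compounds shown here, compound 2, the only other measured compound, gives 4000 nM, a gap far beyond the usual scatter. Compound 3, `COC[C@H](C)N1CCC[C@H](Cn2c(-c3cccnc3C)nc3cn(-c4cccc(OC)c4)nc3c2=O)C1`, has not been measured. It differs from compound 1 in one place: 1-(methoxymethyl)ethyl in place of (oxolan-3-yl)methyl on an amine nitrogen in a ring. For the measured compounds named here, no measured pair shows this change, so the estimate rests on compound 1 alone. Since only the size of the group on the amine changes, the step of a 1.7-fold higher number from compound 1 to compound 3 (0.22 log units; within the scatter) is expected to be small, at most a mild weakening within or near the scatter. Compound 3 is estimated at 100 nM, between 30 nM and 350 nM.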

Compound 3, half-maximal inhibitory concentration: 1.7 nM
Estimate against measurement, compound 3: 59-fold (1.77 log units) above; the whole stated range lies above it.
By their numbers in this assay, from the lowest: compound 3; then compound 1; then compound 2.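

In this assay, the open-chain 1-(methoxymethyl)ethyl in place of the ring-bearing (oxolan-3-yl)methyl gives a 35-fold lower number from compound 1 to compound 3 (1.55 log units; beyond the scatter). The group on this amine nitrogen therefore has a strong bearing on the number, even though both groups have 1 hydrogen-bond acceptor and no net charge. No measurement here bears on the reason for this large step.

From the compounds shown here alone, it remains open whether the loss of the ring or the defined stereocentre accounts for the step. Also open, going by these compounds, is whether a plain isopropyl group, without the ether oxygen, would give a similar number.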